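The source may hold more compounds than are shown below. What is called first, only, known or untested is meant among the compounds shown, and "the series" means these compounds.

Compound 1, `C[Se]c1nc([Se]C)c2cccnc2n1`, stands without a figure: in a functional assay on HT-29 cells (Homo sapiens) for cytotoxicity, read by MTT assay, with a stated time of 72 h (on this read-out lower numbers stand for higher toxicity in this test and higher numbers for lower toxicity in this test), compound 1 gives "not determined" (no result reported). Compound 2, `CSc1nc(NCCCc2ccccc2)c2ccccc2n1`, sits at a limit of the assay, not a number, since in this assay compound 2 gives > 100000 nM; the line the limit of > 100000 nM in this assay, at which 1 of the 2 values shown sits, tells where that limit lies among the values shown. Compound 3, `CSc1nc(NCCCCc2ccccc2)c2ccccc2n1`, differs from compound 2 by benzyl in place of phenyl on a saturated chain carbon, three bonds along the chain from a nitrogen on an aromatic ring. Among the compounds with values here, no measured step speaks to this change, so no shift beyond the scatter is expected, and the step of a number no higher from compound 2 to compound 3 (the limit leaves the size open) is an estimate only. Compound 3 is expected to give about 100000 nM, between 30000 nM and 300000 nM.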

Compound 3, concentration lethal to 50% of the cells: > 100000 nM
Compound 3: a limit, no number; the forecaster's own chance of this, stated with the estimate: 80%; the middle value lies on the limit itself.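

No step can be read between compound 2 and compound 3, as both stand at a limit and neither gives a number: the limit of > 100000 nM in this assay, at which 2 of the 3 values shown sit. The compounds shown leave open how far benzyl in place of phenyl moves the result in this assay at all.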